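This account rests on a few compounds, and the source may have more. Where it says the series, first, only, none or still open, it means among the compounds named here.

Measured in a functional assay on MCF7 cells (Homo sapiens) for antiproliferative activity, read by sulforhodamine B assay, with a stated time of 48 h (a higher number here means a weaker inhibitor, a lower number a stronger inhibitor), so far:
- compound 1 (`COc1cccc(/C=C/C(=O)C(=Cc2ccc(F)cc2)C(=O)/C=C/c2cccc(OC)c2OC)c1OC`) gives 1830 nM 
- compound 2 (`COc1cccc(/C=C/C(=O)C(=Cc2cc(OC)c(OC)c(OC)c2)C(=O)/C=C/c2cccc(OC)c2OC)c1OC`) gives 840 nM 

Compound 2 holds the lower of these two numbers. Compound 3 (`COc1cccc(C=C(C(=O)/C=C/c2cccc(OC)c2OC)C(=O)/C=C/c2cccc(OC)c2OC)c1OC`) is next, with 2,3-dimethoxyphenyl in place of 3,4,5-trimethoxyphenyl on a double-bonded chain carbon bound to a double-bonded chain carbon. Going by the values given here, only one measured step bears on this place: a 2.2-fold lower number from compound 1 to compound 2 (0.34 log units; beyond the scatter) when 3,4,5-trimethoxyphenyl replaced 4-fluorophenyl, a modest change. The group entering compound 3 is neither of those two, so that step offers only a weak guide. Losing 3,4,5-trimethoxyphenyl is expected to raise the number in this assay slightly, by no more than that measured step. The expected change is a 1.4-fold higher number from compound 2 to compound 3 (0.15 log units; within the scatter) and may not be resolved. For compound 3 the estimate is 1200 nM with an expected range from 500 nM to 2900 nM for now.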

Compound 3, half-maximal inhibitory concentration: 520 nM
Estimate against measurement, compound 3: 2.3-fold (0.36 log units) above; measured number inside the range.
By their numbers in this assay, from the lowest: compounds 3 and 2 (each within the scatter of the next); then compound 1.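

In this assay, the place on a double-bonded chain carbon bound to a double-bonded chain carbon accepts 2,3-dimethoxyphenyl as well as 3,4,5-trimethoxyphenyl, with a 1.6-fold lower number from compound 2 to compound 3 (0.21 log units; within the scatter) leaving the two groups unresolved. The 3,4,5-trimethoxyphenyl group is therefore not required to reach this range of values, while 4-fluorophenyl now stands apart from both methoxy-bearing groups, with a 3.5-fold lower number from compound 1 to compound 3 (0.55 log units; beyond the scatter) adding to the earlier step. No measured evidence on the cause of these differences accompanies the numbers.

Going by these compounds, whether methoxy groups are needed here at all stays open, and an unsubstituted phenyl or a dimethylaminophenyl at this place would address that. On these data alone, the two 2,3-dimethoxyphenyl groups carried on the rest of the chain are common to all three compounds, so their contribution also remains unknown.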